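This account rests on a few compounds, and the source may have more. Where it says the series, first, only, none or still open, it means among the compounds named here.

Measured compounds:
compound 1, `Cc1csc(N)c1C(=O)c1ccc(Cl)cc1` — 1%
compound 2, `CC(C)(C)Cc1c(-c2ccc(F)cc2)sc(N)c1C(=O)c1ccc(Cl)cc1` — 9%

Both compounds were tested in an assay on CHO cells for displacement of a labelled ligand from adenosine receptor A3 (Homo sapiens), read by scintillation counting, tested at 10 uM; a lower number here means less inhibition, a higher number more inhibition at the concentration tested (going by the name of the read-out). Compound 1 gives 1%, and compound 2 gives 9%. Compound 2 has the higher of the two numbers, but the gap to compound 1 lies within the usual scatter of repeated measurements, so the two results cannot be told apart with confidence; neither compound shows much displacement of the labelled ligand at the concentration used.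

Compound 3, `CC(C)(C)Cc1c(-c2ccc(Cl)c(Cl)c2)sc(N)c1C(=O)c1ccc(Cl)cc1`, has not yet been measured. It differs from compound 2 in one place: 3,4-dichlorophenyl in place of 4-fluorophenyl on an aromatic carbon. Going by the values given here, no pair of measured compounds shows the effect of this kind of change, so there is no step in the data to lean on. Since compound 2 sits near the bottom of the scale and the structural change is confined to one ring, the step of a number 3 percentage points higher from compound 2 to compound 3 (within the scatter) is expected to be small, and not clearly beyond the scatter in either direction. Compound 3 is therefore expected to give about 12%, with a range from 0% to 35%.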

Compound 3, a percentage reported as inhibition, at one concentration (the size of the read-out at that concentration, not a potency): 1%
For compound 3 the middle estimate is 11 percentage points above the measured one; measured number inside the range.
By their numbers in this assay, from the lowest: compounds 1, 3 and 2 (each within the scatter of the next).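

In this assay, going by these compounds alone, the step of a number 8 percentage points lower from compound 2 to compound 3 (within the scatter) gives the first direct reading at this position, the aromatic carbon next to the ring sulfur. Replacing 4-fluorophenyl with 3,4-dichlorophenyl exchanges one fluorine for two chlorines on the ring, yet the two results cannot be told apart, and both compounds sit near the bottom of the scale at the one concentration tested. Nothing in the available data offers an explanation for this result.

A ring carrying a different kind of substituent, such as an amine or a carboxylic acid, or a longer chain in place of the aryl ring at this position, might give a number clearly beyond the scatter, and the compounds shown cannot say whether it would. The neopentyl, amino and (4-chlorophenyl)carbonyl groups are the same in compound 2 and compound 3, so this pair says nothing about how changes at those places would affect displacement of the labelled ligand.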